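From 4-methoxyphenyl to 3-chlorophenyl

A few compounds are considered here, and "the series" means these few. Any claim that something is new, unique, unknown or untested is made for them only; others in the source may bear on it.

Compound 1 `COC(=O)N1N=C(c2ccc(OC)cc2)CC1c1cc(OC)c(OC)c(OC)c1` – 2590 nM
Compound 2 `CCCOC(=O)N1N=C(c2ccc(OC)cc2)CC1c1cc(OC)c(OC)c(OC)c1` – > 10000 nM (a limit)

Among the compounds with values here, in a functional assay on HeLa cells (Homo sapiens) for antiproliferative activity, read by MTT assay, with a stated time of 48 h (on this read-out lower numbers stand for stronger inhibition of growth and higher numbers for weaker inhibition of growth), compound 1 holds the only true number so far (2590 nM). The value of compound 2 is a limit (> 10000 nM). Compound 3 `COC(=O)N1N=C(c2cccc(Cl)c2)CC1c1cc(OC)c(OC)c(OC)c1` keeps the core of compound 1 and changes one group (3-chlorophenyl in place of 4-methoxyphenyl on a carbon with a double bond to nitrogen), with 3-chlorophenyl in place of 4-methoxyphenyl on a carbon with a double bond to nitrogen. Within the data shown here, the one measured step (an at least 3.8-fold higher number from compound 1 to compound 2 (0.58 log units; beyond the scatter)) changes another part of the molecule, so it offers little guidance here. The expected step (a 1.4-fold higher number from compound 1 to compound 3 (0.13 log units; within the scatter)) is therefore slightly weaker growth inhibition in this assay, not beyond the scatter. For compound 3 the estimated value is 3500 nM (range 900 nM to 12000 nM).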

Compound 3, concentration for 50% growth inhibition: 160 nM
Compound 3: middle estimate off by 22-fold (1.34 log units), on the high side, outside the stated range (below it).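

In this assay the change to 3-chlorophenyl in place of 4-methoxyphenyl gives a 16-fold lower number from compound 1 to compound 3 (1.21 log units; beyond the scatter) and so shows that the group on the carbon with a double bond to nitrogen strongly affects growth inhibition. Within the data shown here, the one earlier step, in another part of the molecule, went towards weaker inhibition, whereas this change at a different place strengthens it. Nothing measured here explains the size of this step.

From the compounds shown here alone, whether the chlorine or its place on the ring matters more stays open. So does how 4-chlorophenyl, 3-methoxyphenyl or a phenyl ring carrying an amine would compare.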